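Ethoxy to Nitro: Estimating the Maximal Response of Compound 4

The source may report more compounds than this note shows. Statements on the series, on what has been measured and on what is new or still open speak of the compounds shown alone.

Measured compounds:
compound 1 `CCOc1ccccc1-c1nc2cc([N+](=O)[O-])ccc2[nH]1` — 46.4%
compound 2 `CN(C)c1ccc(-c2nc3cc(C(F)(F)F)ccc3[nH]2)cc1` — 30.9%
compound 3 `CCOc1ccccc1-c1nc2cc(C(F)(F)F)ccc2[nH]1` — 19.8%

In a functional assay on aorta (Rattus norvegicus, strain Wistar) for inhibition, with a stated time of 60 min (on this read-out lower numbers stand for smaller maximal responses and higher numbers for larger maximal responses), compound 3 gives the smallest maximal response of the three, with compound 2 and compound 1 each sitting higher beyond the scatter. For the measured compounds named here, the only single-change step measured, a number 26.6 percentage points lower from compound 1 to compound 3 (beyond the scatter), concerns the other ring and so does not bear directly on compound 4 `O=[N+]([O-])c1ccccc1-c1nc2cc(C(F)(F)F)ccc2[nH]1`, which differs from compound 3 by nitro in place of ethoxy on an aromatic carbon. Going by the values given here, compound 2, carrying a different group on that ring, gives 30.9%, a higher number than compound 3, but this is no single-change pair. Among the compounds with values here, with no step on the same place, only a loose expectation can be formed. Compound 4 is therefore expected to give 30%, within a range of 15% to 50%. The step of a number 10.2 percentage points higher from compound 3 to compound 4 (beyond the scatter) expected here is a modest rise.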

Compound 4, largest response reached (Emax), in percent of the reference or control that the assay uses: 85.3%
For compound 4 the middle estimate is 55.3 percentage points below the measured one; measured number above the stated range.
By their numbers in this assay, from the lowest: compound 3; then compound 2; then compound 1; then compound 4.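

In this assay, nitro in place of ethoxy on an aromatic carbon ortho to a large group gives a number 65.5 percentage points higher from compound 3 to compound 4 (beyond the scatter) in the first step shown at this place, and it is a large step. The two groups have the same count of heavy atoms, so this count does not separate them. Nothing at hand accounts for the size of the step. As far as these compounds go, whether an amine or a carboxylic acid at this place would give a number closer to that of compound 3 or of compound 4 remains open. Also open, from the compounds shown here alone, is how methoxy would compare with ethoxy here.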